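The compounds below may be only part of what the source reports. "The series", "measured", "known", "first", "only" and "open" are said of these compounds alone.

Compound 1 `CCOC(=O)c1c(-c2cccc(CO)c2)[nH]c2cc(OC)ccc2c1=O`: > 21500 nM (a limit)
Compound 2 `CCOC(=O)c1c(-c2cccc(OC)c2)[nH]c2cc(OC(F)(F)F)ccc2c1=O`: > 21500 nM (a limit)
Compound 3 `CCOC(=O)c1c(-c2cccc(OC)c2)[nH]c2cc(F)cc(F)c2c1=O`: > 21500 nM (a limit)

All three compounds were tested in an ADME assay on BJ cells (Homo sapiens) for cytotoxicity, read by luminescence, with a stated time of 72 h; on this read-out lower numbers stand for an effect already at smaller amounts and higher numbers for an effect only at larger amounts of compound. In this assay compound 3 gives > 21500 nM, which is a limit of the assay and not a number. Compound 3 has no position of its own among the others, since the picture across the set is a single one: the limit of > 21500 nM in this assay, at which 3 of the 3 values shown sit. None of the three compounds yields a number, so the set offers no ranking.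

Compound 4 `CCOC(=O)c1c(-c2cccc(Oc3ccccc3)c2)[nH]c2cc(F)cc(F)c2c1=O` differs from compound 3 in one place, with phenyl in place of methyl on an oxygen on an aromatic ring, a change from methoxy to phenoxy (phenyl in place of methyl on an oxygen on an aromatic ring). The added ring makes this a sizeable structural change. Among the compounds with values here, no measured pair here differs in only one place, so the data offer no direct precedent for it.

The expectation is therefore for no change beyond the usual scatter, in either direction, and most likely another limit rather than a number. The estimated size of the step that the limit leaves unreadable from compound 3 to compound 4 is small. For compound 4 the expected value is 22000 nM. The estimated range for that value runs from 9000 nM to 40000 nM.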

Compound 4, half-maximal effective concentration: > 21500 nM
Compound 4: a limit, no number; the forecaster's own chance of this, stated with the estimate: 75%; the middle value does not contradict the limit.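

In this assay compound 4 gives > 21500 nM, which is a limit and not a number. Compound 3 also stands at a limit, so the step between compound 3 and compound 4 cannot be read, and the picture stays single: the limit of > 21500 nM in this assay, at which 4 of the 4 values shown sit.

The compounds shown leave open what concentration of any of them would produce an effect in this assay, and whether phenoxy in place of methoxy alters it.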